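This account rests on a few compounds, and the source may have more. Where it says the series, first, only, none or still open, it means among the compounds named here.

Measured compounds: compound 1 `Nc1cc(N)c2nc(-c3ccccc3)c(Oc3ccc(Cl)c(Cl)c3)nc2c1`, 14100 nM; compound 2 `COc1cc(CNc2nc3cc(N)cc(N)c3nc2-c2ccccc2)cc(OC)c1OC`, 9550 nM; compound 3 `COc1ccc(Sc2nc3cc(N)cc(N)c3nc2-c2ccccc2)cc1`, < 100000 nM.

In a functional assay on M14 cells (Homo sapiens) for inhibition, read by sulforhodamine B assay, with a stated time of 48 h (a lower number here means a stronger inhibitor of growth, a higher number a weaker inhibitor of growth), compound 1 gives 14100 nM and compound 2 gives 9550 nM. For compound 3 only a limit is known, < 100000 nM, so compound 3 cannot be placed among the numbers; the step that the limit leaves unreadable from compound 1 to compound 3 is therefore unreadable, as the limit of < 100000 nM in this assay, at which 1 of the 3 values shown sits, shows.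

Compound 4 `Nc1cc(N)c2nc(-c3ccccc3)c(Oc3ccc(F)cc3)nc2c1` is not yet measured. It differs from compound 3 by 4-fluorophenoxy in place of (4-methoxyphenyl)sulfanyl on an aromatic carbon. Among the measured compounds shown here, no measured step bears directly on this change, since the only step touching compound 3 is unreadable. The two readable values, from compound 1 and compound 2, suggest where an aryloxy analogue may fall. Compound 4 is expected to give 15000 nM, within 4000 nM to 60000 nM. That estimate means an expected step that the limit leaves unreadable from compound 3 to compound 4.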

Compound 4, concentration for 50% growth inhibition: 17000 nM
The estimate for compound 4 lay 1.1-fold (0.05 log units) below the measured number; measured number inside the range.
By their numbers in this assay, from the lowest: compounds 2, 1 and 4 (each within the scatter of the next).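

Replacing 3,4-dichlorophenyl with 4-fluorophenyl on the oxygen gives a 1.2-fold higher number from compound 1 to compound 4 (0.08 log units; within the scatter). Among the compounds shown here, this is the first readable step at this position, and in this assay it shows that this change in the ring substituents leaves no difference beyond the scatter. The steps from compound 3 cannot be read, as compound 3 carries only a limit: the limit of < 100000 nM in this assay, at which 1 of the 4 values shown sits.

The compounds shown leave open how the number would respond if a carboxylic acid or a simple alkyl chain replaced the phenoxy group at this position.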